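Benzyl in place of cyclohexyl: an expected read-out

The source may hold more compounds than are shown below. What is called first, only, known or untested is meant among the compounds shown, and "the series" means these compounds.

Three compounds have been measured in a functional assay on the whole organism (blood, strain Wistar albino) for inhibition, with Rattus norvegicus as the target, read by colorimetric assay, with stated times of 15 min and 90 min, at a dose of 20 mg/kg by the oral route; a higher number here means more inhibition at the dose given (going by the name of the read-out), a lower number less inhibition:
compound 1 `CCCNC(=O)NS(=O)(=O)c1ccc(-n2nc(-c3ccc(C)cc3)ccc2=O)cc1` gives 109%
compound 2 `CCCCNC(=O)NS(=O)(=O)c1ccc(-n2nc(-c3ccc(C)cc3)ccc2=O)cc1` gives 109%
compound 3 `Cc1ccc(-c2ccc(=O)n(-c3ccc(S(=O)(=O)NC(=O)NC4CCCCC4)cc3)n2)cc1` gives 110%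

All three share one core and differ only in the group on an amide-type nitrogen. The steps among them are small: no change at the digits printed from compound 1 to compound 2 (within the scatter) and a number 1 percentage points higher from compound 1 to compound 3 (within the scatter), and likewise a number 1 percentage points higher from compound 2 to compound 3 (within the scatter). Compound 3 therefore sits together with compound 1 and compound 2, with no separation beyond the scatter.

Compound 4 `Cc1ccc(-c2ccc(=O)n(-c3ccc(S(=O)(=O)NC(=O)NCc4ccccc4)cc3)n2)cc1` is not yet measured. It differs from compound 3 by benzyl in place of cyclohexyl on an amide-type nitrogen. Among the measured compounds shown here, no measured step swaps a saturated ring for an aromatic one; the measured steps only exchange propyl, butyl and cyclohexyl on that nitrogen, and none of them moved the read-out beyond the scatter. On that basis the step of a number 3 percentage points lower from compound 3 to compound 4 (within the scatter) is expected to stay within the scatter as well. Compound 4 is thus estimated at 107% in this assay, with a range from 93% to 120%.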

Compound 4, a percentage reported as inhibition, in the whole organism at one dose (the size of the read-out at that dose, not a potency): 119%
Beside the measured number, compound 4's estimate is 12 percentage points below it; the range from low to high includes it.
By their numbers in this assay, from the lowest: compounds 1, 2, 3 and 4 (each within the scatter of the next).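

In this assay, benzyl brings the first aromatic ring among the groups on this amide-type nitrogen, and swapping it for cyclohexyl gives a number 9 percentage points higher from compound 3 to compound 4 (within the scatter). The open chains give the same picture, with a number 10 percentage points higher from compound 2 to compound 4 (within the scatter) for phenyl in place of propyl and a number 10 percentage points higher from compound 1 to compound 4 (within the scatter) for phenyl in place of ethyl on the saturated chain carbon bound to that nitrogen, so this read-out does not separate a saturated ring, an aromatic ring and an open chain at this position. No measurement given here bears on what lies behind these numbers.

From the compounds shown here alone, whether the read-out would hold with an amine or a carboxylic acid on the phenyl ring, or with a longer chain such as phenylethyl on this nitrogen, stays open. A read-out at a single dose also leaves any difference in potency among these compounds unknown.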